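Amino for hydrogen on the core of compound 2

The source may hold more compounds than are shown below. What is called first, only, known or untested is meant among the compounds shown, and "the series" means these compounds.

For compound 1 `ClCc1ccccc1Cn1cnc2c(Cl)nc(Cl)nc21` the result in a functional assay on OVCAR-4 cells (Homo sapiens) for cytotoxicity, read by sulforhodamine B assay, with a stated time of 48 h (on this read-out higher numbers stand for lower toxicity in this test and lower numbers for higher toxicity in this test), is "not determined" (no result reported). Within the data shown here, compound 2 `ClCc1ccccc1Cn1cnc2c(Cl)ncnc21` gives 45700 nM in this assay, the highest of the two numbers known, while compound 3 `ClCc1cccc(Cn2cnc3nc(Cl)nc(Cl)c32)c1` gives 5370 nM, a gap beyond the scatter. Compound 4 `Nc1nc(Cl)c2ncn(Cc3ccccc3CCl)c2n1` differs from compound 2 by amino in place of hydrogen on an aromatic carbon of a six-membered aromatic ring with 2 nitrogen, part of the fused system, between two ring nitrogen atoms and meta to the chloro group. Among the measured compounds shown here, no pair of measured compounds shows this change, so there is no measured step to lean on. The expectation is a modest shift toward a lower number, a 1.5-fold lower number from compound 2 to compound 4 (0.18 log units; within the scatter), not clearly beyond the scatter. Compound 4 is estimated at 30000 nM, with a range from 6000 nM to 100000 nM.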

Compound 4, concentration lethal to 50% of the cells: 50100 nM
Beside the measured number, compound 4's estimate is 1.7-fold (0.22 log units) below it, and the stated range covers the measured number.
By their numbers in this assay, from the lowest: compound 3; then compounds 2 and 4 (each within the scatter of the next).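

In this assay amino in place of hydrogen on an aromatic carbon between two ring nitrogen atoms gives a 1.1-fold higher number from compound 2 to compound 4 (0.04 log units; within the scatter) and leaves compound 2 and compound 4 indistinguishable on this read-out. This first measured step at this position shows that the carbon can carry amino without a shift beyond the scatter. Nothing measured here bears on the reason for this result. Going by these compounds, whether a methylamino or hydroxyl group on this carbon would read the same remains open. So does whether amino would give the same result on the core of compound 3.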